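This account rests on a few compounds, and the source may have more. Where it says the series, first, only, none or still open, it means among the compounds named here.

Working notes on the amine series built on the shared cage core.

Compound 1 `c1cncc(CN[C@H]2C3C4CC5C6C4CC3C6C52)c1` carries a pyridin-3-ylmethyl group on the amine nitrogen. In an assay on isolated protein for inhibition of Alpha-2B adrenergic receptor (Homo sapiens) (a higher number here means a weaker inhibitor, a lower number a stronger inhibitor), compound 1 gives "not determined" (no result reported), so no number anchors it on the scale. Compound 2 `Fc1cccc(CCCN[C@H]2C3C4CC5C6C4CC3C6C52)c1` likewise gives "not determined" (no result reported) in this assay, leaving it without a single number as well. For the measured compounds named here, the only number in hand comes from compound 3 `COc1cc(CN[C@H]2C3C4CC5C6C4CC3C6C52)cc(OC)c1OC`, which in this assay gives 665 nM.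

Compound 4 `C1CCC(CN[C@H]2C3C4CC5C6C4CC3C6C52)CC1` differs from compound 1 by a single substitution: cyclohexyl in place of pyridin-3-yl on a saturated chain carbon bound to an amine nitrogen. Going by the values given here, no measured pair tracks this change, and compound 1 itself has no value, so neither the direction nor the size of the step in this assay can be read from the present data; any step, beyond or within the scatter, remains open.

Among the compounds with values here, for compound 4 the inhibition constant in this assay is expected to land near 800 nM, with a plausible range from 150 nM to 4000 nM, an estimate resting only on the single number from compound 3 665 nM in this assay.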

Compound 4, inhibition constant: 2540 nM
For compound 4 the middle estimate is 3.2-fold (0.50 log units) below the measured one; low and high end bracket the measured number.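

No step can be read between compound 1 and compound 4: in this assay compound 4 gives 2540 nM while compound 1 has no single number. The compounds shown leave open how cyclohexyl and pyridin-3-yl compare on a saturated chain carbon bound to an amine nitrogen. No supporting evidence bears on this result.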